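The source may report more compounds than this note shows. Statements on the series, on what has been measured and on what is new or still open speak of the compounds shown alone.

The three measured compounds share one core and differ only in the aryl group that sits on the carbonyl carbon. Compound 1 `COc1ccc(-c2cc3ccccc3nc2/C=C/C(=O)c2ccc(F)cc2)cc1` carries a 4-fluorophenyl there, and in a functional assay on SK-BR-3 cells (Homo sapiens) for antiproliferative activity, read by XTT assay, with a stated time of 72 h (a higher number here means a weaker inhibitor, a lower number a stronger inhibitor), compound 1 gives 810 nM. Compound 2 `COc1ccc(-c2cc3ccccc3nc2/C=C/C(=O)c2ccc([N+](=O)[O-])cc2)cc1` carries a 4-nitrophenyl instead; in this assay compound 2 gives 590 nM, and the step is a 1.4-fold lower number from compound 1 to compound 2 (0.14 log units; within the scatter). Compound 3 `COc1ccc(-c2cc3ccccc3nc2/C=C/C(=O)c2ccc(Br)s2)cc1` carries a 5-bromothiophen-2-yl; in this assay compound 3 gives 520 nM, the lowest of the three numbers, although its gaps to the other two both fall within the scatter.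

Compound 4 `COc1ccc(-c2cc3ccccc3nc2/C=C/C(=O)c2sccc2N)cc1` has not yet been measured. Its change from compound 3 is 3-aminothiophen-2-yl in place of 5-bromothiophen-2-yl on a carbonyl carbon. Among the measured compounds shown here, the steps that bear on such an exchange at the carbonyl carbon are a 1.6-fold lower number from compound 1 to compound 3 (0.19 log units; within the scatter) and a 1.1-fold lower number from compound 2 to compound 3 (0.05 log units; within the scatter), both within the scatter, so none of the three aryl groups tried so far has moved the number beyond it. One therefore expects compound 4 to stand close to compound 3, with an estimated step of a 1.2-fold higher number from compound 3 to compound 4 (0.06 log units; within the scatter) in this assay, not beyond the scatter in either direction. Compound 4 is expected to give about 600 nM in this assay, most likely between 250 nM and 1500 nM.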

Compound 4, half-maximal inhibitory concentration: > 10000 nM
Compound 4: no number, only a limit (the forecaster's own chance of this, stated with the estimate: 5%); middle value at least 16-fold (1.22 log units) away from the limit.
By their numbers in this assay, from the lowest: compounds 3, 2 and 1 (each within the scatter of the next). At a limit, above all of these: compound 4.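

In this assay, the carbonyl carbon had carried a 4-fluorophenyl, a 4-nitrophenyl and a 5-bromothiophen-2-yl with no step beyond the scatter, but it does not accept every aryl group: the 3-aminothiophen-2-yl gives an at least 19-fold higher number from compound 3 to compound 4 (1.28 log units; beyond the scatter), along with an at least 16-fold higher number from compound 2 to compound 4 (1.22 log units; beyond the scatter) and an at least 12-fold higher number from compound 1 to compound 4 (1.09 log units; beyond the scatter). Compound 4 stands at a limit of the assay and not at a number, and these steps therefore give only a minimum size: the limit of > 10000 nM in this assay, at which 1 of the 4 values shown sits. The group that leaves and the group that enters are both a five-membered aromatic ring with one hetero atom and have the same count of heavy atoms, which shows that a large step can arise with no change in ring type or size.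

The compounds shown leave open whether the step goes with the amine itself or with its place on the thiophene, which a 3-bromothiophen-2-yl or a 5-aminothiophen-2-yl group could separate. They also leave open whether an amine on a phenyl ring, as in a 4-aminophenyl group, or an acetamide on the thiophene would give a similar result.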